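Swapping the ester group for a dimethyl amide on the shared core

The source may report more compounds than this note shows. Statements on the series, on what has been measured and on what is new or still open speak of the compounds shown alone.

Measured so far:
compound 1 `CCOC(=O)c1sc2nc(SC)nc(-c3cccc(OC)c3)c2c1N` with 4.2%
compound 2 `COc1cccc(-c2nc(SC)nc3sc(C(=O)NN)c(N)c23)c1` with 8.5%
compound 3 `COc1cccc(-c2nc(SC)nc3sc(C(=O)OC(C)(C)C)c(N)c23)c1` with 23.8%

In a functional assay on HEK293 cells for agonist activity at lutropin-choriogonadotropic hormone receptor (Homo sapiens), read by cAMP accumulation (a lower number here means a smaller maximal response, a higher number a larger maximal response), compound 3 stands highest of the three numbers, and both of its gaps to the others are beyond the scatter: compound 2 lies nearest and compound 1 furthest. The pair compound 1 and compound 2 differ only within the scatter, so nothing can be said of their order. Compound 4 `COc1cccc(-c2nc(SC)nc3sc(C(=O)N(C)C)c(N)c23)c1` has not yet been measured in this assay. It differs from compound 3 at one place: dimethylamino in place of tert-butoxy on a carbonyl carbon. Among the compounds with values here, two measured steps bear on this change, since both involve the group on the carbonyl carbon. a number 19.6 percentage points higher from compound 1 to compound 3 (beyond the scatter) and a number 15.3 percentage points higher from compound 2 to compound 3 (beyond the scatter) show that the tert-butyl ester gives the larger response, while the ethoxy ester of compound 1 and the aminoamino group of compound 2 both stay low. Since compound 4 again gives up the tert-butoxy group, a drop in this assay is expected, roughly undoing the gains seen toward compound 3: a number 13.8 percentage points lower from compound 3 to compound 4 (beyond the scatter). Compound 4 is therefore estimated at 10%, with a range from 2% to 26%.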

Compound 4, largest response reached (reported as efficacy), in percent of the reference or control that the assay uses: 11%
For compound 4 the middle estimate is 1 percentage points below the measured one; measured number inside the range.
By their numbers in this assay, from the lowest: compounds 1, 2 and 4 (each within the scatter of the next); then compound 3.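

In this assay the dimethyl amide does not keep the response of the tert-butyl ester: there is a number 12.8 percentage points lower from compound 3 to compound 4 (beyond the scatter), while a number 2.5 percentage points higher from compound 2 to compound 4 (within the scatter) and a number 6.8 percentage points higher from compound 1 to compound 4 (within the scatter) are both small enough to leave these compounds level. On this carbonyl carbon, dimethylamino, aminoamino and ethoxy now all sit at the same low level, so among these four compounds only tert-butoxy stands apart, and being an ester is not enough, as the ethoxy ester of compound 1 shows. No measurement here explains why tert-butoxy differs from the other three groups.

The compounds shown leave open whether the tert-butyl group itself carries the larger response, which a tert-butyl amide on the same carbonyl carbon could test. From the compounds shown here alone, how an isopropyl ester or a carboxylic acid would read at this place also remains unknown.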